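Solubility notes on the shared core, toward compound 4

This account rests on a few compounds, and the source may have more. Where it says the series, first, only, none or still open, it means among the compounds named here.

Measured so far:
compound 1, `CNC(=O)c1cc(C(=O)N[C@H]2[C@@H]3C[C@H](O)C[C@@H]32)n([C@@H](C)c2cccc(Cl)c2)n1`: >= 168 ug/mL
compound 2, `CNC(=O)c1cc(C(=O)N[C@H]2CC[C@H](O)CC2)n([C@@H](C)c2cccc(Cl)c2)n1`: >= 143 ug/mL
compound 3, `CNC(=O)c1cc(C(=O)N[C@H]2[C@@H]3C[C@@H](O)C[C@@H]32)n([C@@H](C)c2cccc(Cl)c2)n1`: 175 ug/mL

In a physicochemical assay for solubility, measured as kinetic solubility (a lower number here means a less soluble compound, a higher number a more soluble compound), compound 2 gives >= 143 ug/mL, which is a limit of the assay and not a number. Compound 1 also sits at a limit, so the steps a step that the two limits leave unreadable from compound 1 to compound 2 and a step that the limit leaves unreadable from compound 2 to compound 3 cannot be read in size. Compound 4, `CC[C@@H](c1ccccc1)n1nc(C(=O)NC)cc1C(=O)N[C@H]1CC[C@H](O)CC1`, differs from compound 2 by 1-phenylpropyl in place of 1-(3-chlorophenyl)ethyl on an aromatic nitrogen. Within the data shown here, none of the measured steps bears on this change; they concern only the group on the amide-type nitrogen and the configuration as drawn. With compound 2 standing at the limit of >= 143 ug/mL in this assay, at which 1 of the 3 values shown sits, no step beyond the scatter is expected, and the expected step is a step that the limit leaves unreadable from compound 2 to compound 4. Compound 4 is therefore estimated at 150 ug/mL, in the range 70 ug/mL to 300 ug/mL, with a fair chance that only a limit is returned.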

Compound 4, solubility: 138 ug/mL
Compound 4: middle estimate off by 1.1-fold (0.04 log units), on the high side; the measured number falls inside the stated range.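

Among these compounds, compound 4 gives the first readable number for a change on the aromatic nitrogen, a place where the earlier compounds all carry 1-(3-chlorophenyl)ethyl. In this assay, 1-phenylpropyl in place of 1-(3-chlorophenyl)ethyl gives an at least 1.0-fold lower number from compound 2 to compound 4 (0.01 log units; that floor lies within the scatter). The full size of this step cannot be read, since compound 2 sits at a limit of the assay: the limit of >= 143 ug/mL in this assay, at which 1 of the 4 values shown sits.

Loss of the chlorine and the longer chain stand together in this one step, and 1-phenylethyl would part them. On these data alone, how an amine or a carboxylic acid on this group would read in this assay stays open.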